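Swapping a sulfonamide methyl for pyrimidin-5-yl

The source may hold more compounds than are shown below. What is called first, only, known or untested is meant among the compounds shown, and "the series" means these compounds.

Measured in a physicochemical assay for solubility, read by spectrophotometry, measured as kinetic solubility, at pH 8, tested at 500 uM; on this read-out higher numbers stand for higher solubility and lower numbers for lower solubility:
- compound 1 `CN1CCC(CNS(=O)(=O)c2ccccc2Nc2cc(-c3ccc4ccn(C)c4c3)c3nccnc3c2)C1`: 35 ug/mL
- compound 2 `Cn1ccc2ccc(-c3cc(Nc4ccccc4S(N)(=O)=O)cc4nccnc34)cc21`: 6 ug/mL
- compound 3 `CNS(=O)(=O)c1ccccc1Nc1cc(-c2ccc3ccn(C)c3c2)c2nccnc2c1`: 2 ug/mL

Compound 3 stands lowest of the three. Compound 4 `Cn1ccc2ccc(-c3cc(Nc4ccccc4S(=O)(=O)Nc4cncnc4)cc4nccnc34)cc21` differs from it in one place, with pyrimidin-5-yl in place of methyl on a sulfonamide nitrogen. Two measured steps end at this same methyl: there is a 3.0-fold lower number from compound 2 to compound 3 (0.48 log units; beyond the scatter), a modest step, and an 18-fold lower number from compound 1 to compound 3 (1.24 log units; beyond the scatter), a large one. Going by the values given here, both show compound 3 below its neighbours, but no measured compound carries pyrimidin-5-yl, so the size stays uncertain. In this assay, a modest rise is expected, an estimated 5.0-fold higher number from compound 3 to compound 4 (0.70 log units; beyond the scatter). The expected value for compound 4 is 10 ug/mL, with an estimated range of 3 ug/mL to 40 ug/mL.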

Compound 4, solubility: 254 ug/mL
The estimate for compound 4 lay 25-fold (1.40 log units) below the measured number, outside the stated range (above it).
By their numbers in this assay, from the lowest: compound 3; then compound 2; then compound 1; then compound 4.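

In this assay this sulfonamide nitrogen takes a six-membered aromatic ring and gives the highest number of the four, with a 130-fold higher number from compound 3 to compound 4 (2.10 log units; beyond the scatter) and a 42-fold higher number from compound 2 to compound 4 (1.63 log units; beyond the scatter) when the ring replaces the smaller groups. A high number at this position therefore does not depend on the (1-methylpyrrolidin-3-yl)methyl chain, since the ring passes that chain too (a 7.3-fold higher number from compound 1 to compound 4 (0.86 log units; beyond the scatter)). Whether phenyl, with no ring nitrogen, or pyridin-3-yl would do the same stays open, and nothing shown gives the reason for the rise.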